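A few compounds are considered here, and "the series" means these few. Any claim that something is new, unique, unknown or untested is made for them only; others in the source may bear on it.

Among the measured compounds shown here, in an assay on isolated protein for binding affinity to 5-hydroxytryptamine receptor 6 (Homo sapiens) (on this read-out higher numbers stand for weaker inhibition and lower numbers for stronger inhibition), compound 2 `COc1ccc(S(=O)(=O)Nc2cc(Br)cc(Br)c2Cl)cc1N1CCNCC1` gives 2.51 nM, the lowest of the two numbers measured so far, while compound 1 `COc1ccc(S(=O)(=O)Nc2c(F)cc(Br)cc2F)cc1N1CCNCC1` gives 158 nM. Compound 3 `COc1ccc(S(=O)(=O)Nc2cc(Br)cc(Br)c2F)cc1N1CCNCC1` differs from compound 2 by fluoro in place of chloro on an aromatic carbon. For the measured compounds named here, the single measured step, a 63-fold lower number from compound 1 to compound 2 (1.80 log units; beyond the scatter), changes the whole substitution pattern of that ring at once, so the halogen exchange alone cannot be separated from it; no measured pair isolates fluoro against chloro. A modest step toward a higher number, if any, is therefore expected in this assay. For compound 3 the estimate is 4.5 nM, range 1.5 nM to 14 nM. This corresponds to an expected step of a 1.8-fold higher number from compound 2 to compound 3 (0.25 log units; within the scatter).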

Compound 3, inhibition constant: 2.51 nM
Estimate against measurement, compound 3: 1.8-fold (0.25 log units) above, and the stated range covers the measured number.
By their numbers in this assay, from the lowest: compounds 2 and 3 (each within the scatter of the next); then compound 1.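

In this assay, fluoro and chloro at this place on the 3,5-dibromophenyl pattern are not told apart: the exchange gives no change at the digits printed from compound 2 to compound 3 (within the scatter). The large difference from compound 1 also holds with fluoro, at a 63-fold lower number from compound 1 to compound 3 (1.80 log units; beyond the scatter), so it does not depend on chloro at this place. Nothing available explains this equivalence of the two halogens.

On these data alone, whether a methyl group, a nitrile or plain hydrogen at this place would keep the number stays open. Also open, as far as these compounds go, is how much of the difference from compound 1 belongs to each bromo group, as that step changes several places on the ring at once.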